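A few compounds are considered here, and "the series" means these few. Any claim that something is new, unique, unknown or untested is made for them only; others in the source may bear on it.

Three members of the series share one core and differ only in the saturated chain on the ring nitrogen. Compound 1 `CCCCN1NN=C(NC(=O)Nc2c(C(C)C)cccc2C(C)C)N1` gives 92 nM in an assay on microsomes from intestine for inhibition of acyl-CoA:cholesterol acyltransferase (Oryctolagus cuniculus); on this read-out lower numbers stand for stronger inhibition and higher numbers for weaker inhibition. Compound 2 `CCCCCCCCN1NN=C(NC(=O)Nc2c(C(C)C)cccc2C(C)C)N1` gives 59 nM in this assay, and compound 3 `CCCCCCCCCN1NN=C(NC(=O)Nc2c(C(C)C)cccc2C(C)C)N1` gives 31 nM. On these numbers compound 2 stands second highest of the three, with compound 1 nearest and compound 3 furthest. The measured steps are a 1.6-fold lower number from compound 1 to compound 2 (0.19 log units; within the scatter), a 3.0-fold lower number from compound 1 to compound 3 (0.47 log units; beyond the scatter) and a 1.9-fold lower number from compound 2 to compound 3 (0.28 log units; within the scatter): each chain extension moves the number down, but only the longest extension clears the scatter.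

Compound 4 `CCCCCCCCCCCCCN1NN=C(NC(=O)Nc2c(C(C)C)cccc2C(C)C)N1` is not yet measured. It differs from compound 2 by pentyl in place of hydrogen on a saturated chain carbon, eight bonds along the chain from an amine nitrogen in a ring. For the measured compounds named here, the step from compound 2 to compound 3 is the nearest precedent and stays within the scatter; the step from compound 1 to compound 3 shows that a longer extension can give a modest gain. The expectation for compound 4 is therefore a modest step down, a 2.0-fold lower number from compound 2 to compound 4 (0.29 log units; within the scatter). The estimated value for compound 4 is 30 nM, with a range from 10 nM to 100 nM.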

Compound 4, half-maximal inhibitory concentration: 9 nM
Estimate against measurement, compound 4: 3.3-fold (0.52 log units) above, and the stated range ends above it.
By their numbers in this assay, from the lowest: compound 4; then compounds 3, 2 and 1 (each within the scatter of the next, the first and the last beyond it).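

Lengthening the chain on the ring nitrogen still lowers the number in this assay beyond compound 3: there is a 3.4-fold lower number from compound 3 to compound 4 (0.54 log units; beyond the scatter), and a 6.6-fold lower number from compound 2 to compound 4 (0.82 log units; beyond the scatter), so this pentyl change clears the scatter, whereas the methyl change on compound 2 does not. Over the whole series there is a 10-fold lower number from compound 1 to compound 4 (1.01 log units; beyond the scatter), the only large step here, and compound 4 stands beyond the scatter of each of the other three, making it the strongest inhibitor of the four. The pentyl change reads alike whether it is made on the shorter or the longer chain: the same change on two cores in this assay, a 3.0-fold lower number (0.47 log units; beyond the scatter) from compound 1 to compound 3 and a 6.6-fold lower number (0.82 log units; beyond the scatter) from compound 2 to compound 4, 2.2-fold (0.34 log units) apart, within the scatter of two such steps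

Going by these compounds, whether the number keeps falling with a longer chain than that of compound 4, or levels off or turns back, stays open. Also open, on these data alone, is how a branched chain, or a chain ending in an amine or a carboxylic acid, would read at this position.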